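The source may hold more compounds than are shown below. What is called first, only, known or untested is meant among the compounds shown, and "the series" means these compounds.

Working notes on the series.

In an assay on HL-60 cells for inhibition of glutathione S-transferase P (Homo sapiens), read by spectrophotometry, tested at 20 uM (a higher number here means more inhibition at the concentration tested (going by the name of the read-out), a lower number less inhibition), compound 1 `CCOc1ccc(/C=C2\CN(CC(=O)O)c3c(C)cccc3C2=O)cc1` gives 42.4%. In this assay compound 2 `CCOc1ccccc1/C=C1\CN(CC(=O)O)c2c(Cl)cccc2C1=O` gives 19.7%, and compound 3 `CCOc1ccccc1/C=C1\CN(CC(=O)O)c2c(C)cccc2C1=O` gives 15.4%. Compound 1 stands highest of the three, above compound 2 and compound 3 by margins beyond the scatter. The difference between the core of compound 1 and the core of compound 3 is not broken down here; the two hold the same atoms joined differently.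

Compound 3 and compound 2 differ in one place: chloro in place of methyl on an aromatic carbon. That change gives a number 4.3 percentage points higher from compound 3 to compound 2 (within the scatter), a step that stays within the scatter, so nothing beyond a flat result can be read from it.

Compound 4 `CCOc1ccc(/C=C2\CN(CC(=O)O)c3c(Cl)cccc3C2=O)cc1` is not yet measured in this assay. It differs from compound 1 by chloro in place of methyl on an aromatic carbon, the same change as from compound 3 to compound 2, with the place described in the same words. The expected step is a number 2.6 percentage points higher from compound 1 to compound 4 (within the scatter), a small one, because a number 4.3 percentage points higher from compound 3 to compound 2 (within the scatter) shows the same change doing little on the other core. On that basis compound 4 is expected to give about 45% in this assay, with a range of 30% to 60%; the estimate rests on a single matched pair and on compound 1 as the starting point.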

Compound 4, a percentage reported as inhibition, at one concentration (the size of the read-out at that concentration, not a potency): 59.1%
The estimate for compound 4 lay 14.1 percentage points below the measured number; measured number inside the range.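

In this assay, chloro in place of methyl on an aromatic carbon of the core of compound 1 gives a number 16.7 percentage points higher from compound 1 to compound 4 (beyond the scatter). Set beside the same change on the core of compound 3, the two steps cannot be told apart, so the series offers no sign that the result of this change depends on the core: the same change on two cores in this assay, a number 4.3 percentage points higher (within the scatter) from compound 3 to compound 2 and a number 16.7 percentage points higher (beyond the scatter) from compound 1 to compound 4, 12.4 percentage points apart, within the scatter of two such steps This does not show that the step has the same size on both cores, nor that a reliable gain carries from one to the other, since only two matched pairs are available, only one of the steps lies beyond the scatter, and neither pair says why the numbers move.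

On these data alone, what a bromo, a methoxy or an amine would do on that aromatic carbon stays open, as does the effect of an ester or an amide in place of the carboxylic acid that all four compounds carry. As far as these compounds go, with a read-out at a single concentration, how these compounds compare in potency also stays open.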